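Phenoxy in place of pyridinyl on the shared core

The source may hold more compounds than are shown below. What is called first, only, known or untested is meant among the compounds shown, and "the series" means these compounds.

Compound 1 `Cc1cccc(-c2ccc(CCC(=O)N3CCCC3)cc2)c1`: in an assay on HEK293 cells for inhibition of N-acylethanolamine-hydrolyzing acid amidase (Rattus norvegicus), read by LC-MS, with a stated time of 30 min (on this read-out higher numbers stand for weaker inhibition and lower numbers for stronger inhibition), compound 1 gives 16500 nM.
Compound 2 `O=C(CCc1ccc(-c2ccccc2Cl)cc1)N1CCCC1`: compound 2 gives only a limit of the assay, > 100000 nM.
Compound 3 `O=C(CCc1ccc(-c2ccccn2)cc1)N1CCCC1`: compound 3 likewise gives only a limit of the assay, > 100000 nM.

Compound 3 thus stands at the limit, not at a number, and it shares this with one other compound (the limit of > 100000 nM in this assay, at which 2 of the 3 values shown sit). The unmeasured compound 4 `O=C(CCc1ccc(Oc2ccccc2)cc1)N1CCCC1` differs from compound 3 by phenoxy in place of pyridin-2-yl on an aromatic carbon. Among the measured compounds shown here, no measured step swaps exactly these two groups. The nearest guides are an at least 6.0-fold higher number from compound 1 to compound 3 (0.78 log units; beyond the scatter), an at least 6.0-fold higher number from compound 1 to compound 2 (0.78 log units; beyond the scatter) and a step that the two limits leave unreadable from compound 2 to compound 3. Only compound 1, with a carbon-only ring at this place, gave a readable number; compound 4 also carries a carbon-only ring there, so a number rather than a limit seems plausible, yet weak binding is still expected. Compound 4 is estimated at 50000 nM, with a range from 10000 nM to 150000 nM, meaning an at least 2.0-fold lower number from compound 3 to compound 4 (0.30 log units; that floor lies within the scatter).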

Compound 4, half-maximal inhibitory concentration: > 100000 nM
Compound 4 was reported as a limit; the forecaster's own chance of this, stated with the estimate: 40%; middle value at least 2.0-fold (0.30 log units) from the limit.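

Phenoxy, the only group shown that holds its ring through an oxygen, also gives just a limit of the assay: the limit of > 100000 nM in this assay, at which 3 of the 4 values shown sit.

Set against compound 1, the only readable value, the change to phenoxy gives an at least 6.0-fold higher number from compound 1 to compound 4 (0.78 log units; beyond the scatter). The steps among compound 2, compound 3 and compound 4 cannot be read.

Still open, from the compounds shown here alone, is whether a 3-methoxyphenyl or benzyloxy group at this place would give a readable number. The limits also leave open how weak compound 2, compound 3 and compound 4 really are, or how they rank against one another.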